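Dropping the Methoxy Group: From Compound 3 to Compound 4

The source may hold more compounds than are shown below. What is called first, only, known or untested is meant among the compounds shown, and "the series" means these compounds.

Of the compounds shown here, three sharing one core have been measured in an assay on isolated protein for binding affinity to 5-hydroxytryptamine receptor 3A (Homo sapiens); on this read-out higher numbers stand for weaker inhibition and lower numbers for stronger inhibition. Compound 1 `Fc1cccc(-c2n[nH]cc2N2CCCNCC2)c1` gives 656 nM, compound 2 `Fc1ccc(-c2n[nH]cc2N2CCCNCC2)cc1` gives 1810 nM, and compound 3 `COc1ccc(-c2n[nH]cc2N2CCCNCC2)cc1` gives 1230 nM. On these numbers compound 3 stands within the usual scatter of both neighbours: its gap to compound 2 and its gap to compound 1 are each too small to count as a real difference, so none of the three can be called stronger or weaker than another.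

Compound 4 `c1ccc(-c2n[nH]cc2N2CCCNCC2)cc1` differs from compound 3 in one place: hydrogen in place of methoxy on an aromatic carbon. For the measured compounds named here, only one measured step touches the same aromatic carbon, namely a 1.5-fold lower number from compound 2 to compound 3 (0.17 log units; within the scatter), where methoxy took the place of fluoro without leaving the scatter. Compound 1 and compound 2 differ only in where the fluoro sits, and their two values, too, lie within the scatter of each other. Going by the values given here, nothing measured so far suggests that a group at this position moves the number much either way, so the expected step of a 1.0-fold lower number from compound 3 to compound 4 (0.01 log units; within the scatter) is no change beyond the scatter. Compound 4 is therefore estimated to give about 1200 nM in this assay, between 500 nM and 3000 nM.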

Compound 4, inhibition constant: 2100 nM
Beside the measured number, compound 4's estimate is 1.8-fold (0.24 log units) below it; low and high end bracket the measured number.
By their numbers in this assay, from the lowest: compounds 1, 3, 2 and 4 (each within the scatter of the next, the first and the last beyond it).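

With hydrogen on the aromatic carbon para to a large group, compound 4 shows in this assay that this carbon can carry no group at all without leaving the scatter, since both a 1.7-fold higher number from compound 3 to compound 4 (0.23 log units; within the scatter) and a 1.2-fold higher number from compound 2 to compound 4 (0.06 log units; within the scatter) stay inside it. Neither methoxy nor the fluoro of compound 2 can therefore be told apart from hydrogen at this carbon, which the earlier comparison of methoxy with fluoro alone could not show. For the compounds shown here, the one step that clears the scatter is the modest 3.2-fold higher number from compound 1 to compound 4 (0.51 log units; beyond the scatter) for the fluoro of compound 1, whose place on the ring differs from that of compound 2, so the placing of fluoro now counts for more than any group at this carbon, though nothing given here accounts for that step.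

Going by these compounds, it remains open whether an amine, a carboxylic acid or a longer chain such as butoxy at this carbon would also stay within the scatter of hydrogen. Also open, on these data alone, is whether methoxy placed where compound 1 carries its fluoro would give a step like the one fluoro gives there.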